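Replacing a Hydroxyphenyl with a Fluorophenyl: Expected Loss

This account rests on a few compounds, and the source may have more. Where it says the series, first, only, none or still open, it means among the compounds named here.

Compound 1 `O=C(c1sc(-c2cccc(F)c2)nc1O)N1CCOC1` gives 5500 nM in an assay on HEK293 cells for inhibition of transient receptor potential cation channel subfamily M member 8 (Homo sapiens), read by FLIPR, with stated times of 5 min and 3 min; a higher number here means a weaker inhibitor, a lower number a stronger inhibitor.
Compound 2 `O=C(c1sc(-c2cccc(F)c2)nc1O)N1CCCOC1` gives only a limit of the assay, > 100000 nM.
Compound 3 `O=C(c1sc(-c2ccccc2O)nc1O)N1CCCCO1` gives 81 nM.

Of the two numbers in this assay, compound 3 has the lowest, and its gap to compound 1 lies beyond the usual scatter. Compound 4 `O=C(c1sc(-c2cccc(F)c2)nc1O)N1CCCCO1` keeps the amide ring of compound 3 and differs from it in one place: 3-fluorophenyl in place of 2-hydroxyphenyl on an aromatic carbon. Among the measured compounds shown here, no measured step covers this exact change, so its size has to be judged from the surroundings. For the measured compounds named here, the only measured step, an at least 18-fold higher number from compound 1 to compound 2 (1.25 log units; beyond the scatter), alters the amide ring rather than the aryl group and shows how sharply this assay can respond to a single change; that step ends at the limit of > 100000 nM in this assay, at which 1 of the 3 values shown sits. Going by the values given here, both compounds carrying the 3-fluorophenyl group, compound 1 and compound 2, give high numbers or a limit, while the one compound carrying the 2-hydroxyphenyl group, compound 3, gives the low number. On that basis compound 4 is expected to give a clearly higher number than compound 3, with the step of a 37-fold higher number from compound 3 to compound 4 (1.57 log units; beyond the scatter) estimated to lie beyond the scatter. The estimate for compound 4 in this assay is 3000 nM, between 500 nM and 30000 nM.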

Compound 4, half-maximal inhibitory concentration: 167 nM
The estimate for compound 4 lay 18-fold (1.25 log units) above the measured number; the measured number lies below the stated range.
By their numbers in this assay, from the lowest: compound 3; then compound 4; then compound 1. At a limit, above all of these: compound 2.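

In this assay, the step is a 2.1-fold higher number from compound 3 to compound 4 (0.31 log units; beyond the scatter), which is modest though beyond the scatter. At this aromatic carbon, then, 3-fluorophenyl, with no hydrogen-bond donor or acceptor, gives a number close to that of 2-hydroxyphenyl, with one of each, so a low number among these compounds does not depend on the hydroxy group. The high numbers of the earlier fluorinated compounds go with their amide rings instead: with 3-fluorophenyl held constant, the ring change gives a 33-fold lower number from compound 1 to compound 4 (1.52 log units; beyond the scatter) and, starting from a value that is a limit of the assay, an at least 590-fold lower number from compound 2 to compound 4 (2.77 log units; beyond the scatter), both large steps.

The compounds shown leave open whether the modest step comes from the change of group or from its place on the phenyl ring, a question that 2-fluorophenyl and 3-hydroxyphenyl on the same amide would separate. They also leave open how far this position tolerates other groups, such as a plain phenyl, an aminophenyl or a carboxylic acid on the phenyl ring.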